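Furan-2-yl replacing methoxyphenyl on the shared core

The compounds below may be only part of what the source reports. "The series", "measured", "known", "first", "only" and "open" are said of these compounds alone.

The series is followed in an assay on cells (Endothelial cell) for binding affinity to Endothelin-1 receptor (Sus scrofa); on this read-out higher numbers stand for weaker inhibition and lower numbers for stronger inhibition. Compound 1 `CCc1ccc(-c2c(NS(=O)(=O)c3ccc(C(C)(C)C)cc3)ncnc2OCCOc2ncc(SC)cn2)cc1` gives 0.013 nM. Compound 2 `CSc1cnc(OCCOc2ncnc(NS(=O)(=O)c3ccc(C(C)(C)C)cc3)c2-c2ccc(C(F)(F)F)cc2)nc1` gives 0.0017 nM. Compound 3 `COc1ccc(-c2c(NS(=O)(=O)c3ccc(C(C)(C)C)cc3)ncnc2OCCOc2ncc(SC)cn2)cc1` stands at < 0.001 nM, which is a limit of this assay and not a number, as noted in the limit of < 0.001 nM in this assay, at which 1 of the 3 values shown sits. On the values shown compound 3 therefore sits at the floor of the series, and only a bound is known for it.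

The measured steps on the aromatic substituent are a 7.6-fold lower number from compound 1 to compound 2 (0.88 log units; beyond the scatter), an at least 13-fold lower number from compound 1 to compound 3 (1.11 log units; beyond the scatter) and an at least 1.7-fold lower number from compound 2 to compound 3 (0.23 log units; that floor lies within the scatter). Compound 4 `CSc1cnc(OCCOc2ncnc(NS(=O)(=O)c3ccc(C(C)(C)C)cc3)c2-c2ccco2)nc1` carries furan-2-yl in place of 4-methoxyphenyl on an aromatic carbon. Within the data shown here, none of the measured steps exchanges the ring itself, so they give only the spread of values that substituent changes produced here. From the compounds shown here alone, the expectation for compound 4 is a move to a higher number in this assay, an at least 10-fold higher number from compound 3 to compound 4 (1.00 log units; beyond the scatter), since the measured compounds lie tightly around the floor and the new ring is untested. The estimate for compound 4 is 0.01 nM, between 0.001 nM and 0.1 nM.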

Compound 4, half-maximal inhibitory concentration: 2.9 nM
Estimate against measurement, compound 4: 290-fold (2.46 log units) below; measured number outside the range, above it.
By their numbers in this assay, from the lowest: compound 2; then compound 1; then compound 4. At a limit, below all of these: compound 3.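

In this assay, this position accepts changes of the group on the phenyl ring far better than replacement of the ring itself: a 1700-fold higher number from compound 2 to compound 4 (3.23 log units; beyond the scatter) and a 220-fold higher number from compound 1 to compound 4 (2.35 log units; beyond the scatter), both larger than any substituent step seen earlier. Compound 3 carries a limit and not a number, so the step from it is only a bound, an at least 2900-fold higher number from compound 3 to compound 4 (3.46 log units; beyond the scatter): the limit of < 0.001 nM in this assay, at which 1 of the 4 values shown sits. The direction is the same for all three pairs, with 4-ethylphenyl, 4-(trifluoromethyl)phenyl and 4-methoxyphenyl all on the low side of furan-2-yl.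

The compounds shown do not separate the change from a six-membered to a five-membered ring from the loss of the substituent. Unsubstituted phenyl and a furan-2-yl carrying a methyl group would tell these two apart.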